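Working notes: changing the group on the sulfonyl sulfur

This account rests on a few compounds, and the source may have more. Where it says the series, first, only, none or still open, it means among the compounds named here.

Measured so far in a functional assay on LOX IMVI cells (Homo sapiens) for cytotoxicity, read by MTT assay, with a stated time of 24 h; a lower number here means a stronger inhibitor, a higher number a weaker inhibitor:
- compound 1 `COc1cc(-c2nc(-c3ccccc3)[nH]c2-c2ccnc(NCCCNS(=O)(=O)c3cccc(F)c3)n2)ccc1F`, 900 nM
- compound 2 `O=S(=O)(NCCCNc1nccc(-c2[nH]c(-c3ccccc3)nc2-c2ccc(Cl)c(O)c2)n1)c1ccc(Cl)cc1`, 61300 nM
- compound 3 `O=S(=O)(NCCCNc1nccc(-c2[nH]c(-c3ccccc3)nc2-c2ccc(Cl)c(O)c2)n1)c1ccc(C(F)(F)F)cc1`, 10100 nM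

Compound 3 holds the second highest of the three numbers, with compound 2 higher and compound 1 lower. The next change leads to compound 4 `O=S(=O)(NCCCNc1nccc(-c2[nH]c(-c3ccccc3)nc2-c2ccc(Cl)c(O)c2)n1)c1cccc(F)c1` and is 3-fluorophenyl in place of 4-(trifluoromethyl)phenyl on a sulfonyl sulfur. For the measured compounds named here, the one measured step on this group is a 6.1-fold lower number from compound 2 to compound 3 (0.78 log units; beyond the scatter), modest and beyond the scatter. Compound 1 carries the same 3-fluorophenyl with a different group elsewhere, and it gives 900 nM, which points toward lower numbers. A similarly modest step is expected in this assay, estimated as a 2.2-fold lower number from compound 3 to compound 4 (0.35 log units; beyond the scatter). Compound 4 is expected at 4500 nM, within a range from 1000 nM to 20000 nM.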

Compound 4, half-maximal inhibitory concentration: 33600 nM
Estimate against measurement, compound 4: 7.5-fold (0.87 log units) below; the measured number lies above the stated range.
By their numbers in this assay, from the lowest: compound 1; then compound 3; then compounds 4 and 2 (each within the scatter of the next).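

On the shared core carrying 4-chloro-3-hydroxyphenyl, this assay gives a 3.3-fold higher number from compound 3 to compound 4 (0.52 log units; beyond the scatter) and so 4-(trifluoromethyl)phenyl keeps the lowest number of the three sulfonyl groups. The reading a 1.8-fold lower number from compound 2 to compound 4 (0.26 log units; within the scatter) leaves 3-fluorophenyl and 4-chlorophenyl level. With 3-fluorophenyl held constant, the change on the aromatic carbon gives a 37-fold higher number from compound 1 to compound 4 (1.57 log units; beyond the scatter) and is larger than any step on the sulfonyl sulfur. No measurement on hand accounts for these differences.

Still open, going by these compounds, is whether the order of sulfonyl groups holds with 4-fluoro-3-methoxyphenyl on the core. Also open, on these data alone, is how a methyl group or an aminophenyl on the sulfonyl sulfur would read.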